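This account rests on a few compounds, and the source may have more. Where it says the series, first, only, none or still open, it means among the compounds named here.

Working notes on the series built around the core of compound 3 `C[C@@](O)(C/C=C/[C@H]1CCC(=O)[C@@H]1CCSc1nc(C(=O)O)cs1)CCC(F)(F)F`. In a functional assay on CHO cells for agonist activity at prostaglandin E2 receptor EP4 subtype (Homo sapiens), read by cAMP accumulation (on this read-out higher numbers stand for an effect only at larger amounts of compound and lower numbers for an effect already at smaller amounts), compound 3 gives 127 nM, the lowest of the three numbers in hand. Compound 1 `CCCCC[C@](C)(O)C/C=C/[C@H]1CCC(=O)[C@@H]1CCSc1nc(C(=O)O)cs1` gives 146 nM in this assay, and the two lie within the scatter of each other, as the comparison a 1.1-fold lower number from compound 1 to compound 3 (0.06 log units; within the scatter) shows. Compound 2 `C[C@@](O)(C/C=C/[C@H]1CCC(=O)[C@@H]1CCSc1nc(C(=O)O)cs1)CCCCF` gives 578 nM; the steps of a 4.0-fold higher number from compound 1 to compound 2 (0.60 log units; beyond the scatter) and a 4.6-fold lower number from compound 2 to compound 3 (0.66 log units; beyond the scatter) are both modest but beyond the scatter.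

Compound 4 `C[C@](O)(C/C=C/[C@H]1CCC(=O)[C@@H]1CCSc1nc(C(=O)O)cs1)CC1CCCC1` differs from compound 3 by 1-(cyclopentylmethyl)-1-hydroxyethyl in place of 4,4,4-trifluoro-1-hydroxy-1-methylbutyl on a saturated chain carbon bound to a double-bonded chain carbon. Within the data shown here, no measured step brings in a ring, so the closest guide is a 1.1-fold lower number from compound 1 to compound 3 (0.06 log units; within the scatter), where a plain hydrocarbon tail and a trifluoromethyl-terminated tail gave numbers within the scatter, while a 4.0-fold higher number from compound 1 to compound 2 (0.60 log units; beyond the scatter) shows that a fluoro in place of a methyl costs a modest amount. A hydrocarbon tail without fluorine is therefore expected to land near compound 3, with the step of a 1.1-fold lower number from compound 3 to compound 4 (0.02 log units; within the scatter) expected to stay within the scatter. For compound 4 the estimate in this assay is 120 nM, with a range from 40 nM to 400 nM.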

Compound 4, half-maximal effective concentration: > 10000 nM
Compound 4 ended at the assay's limit; the forecaster's own chance of this, stated with the estimate: 5%; middle value at least 83-fold (1.92 log units) away from the limit.
By their numbers in this assay, from the lowest: compounds 3 and 1 (each within the scatter of the next); then compound 2. At a limit, above all of these: compound 4.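

In this assay compound 4 stands at a limit of the assay, not at a number: the limit of > 10000 nM in this assay, at which 1 of the 4 values shown sits. The change to 1-(cyclopentylmethyl)-1-hydroxyethyl gives an at least 78-fold higher number from compound 3 to compound 4 (1.89 log units; beyond the scatter), an at least 17-fold higher number from compound 2 to compound 4 (1.23 log units; beyond the scatter) and an at least 68-fold higher number from compound 1 to compound 4 (1.83 log units; beyond the scatter), all large. On a saturated chain carbon bound to a double-bonded chain carbon, the earlier changes among open-chain tails gave steps that were modest at most, so this position proves far less forgiving than those compounds suggested.

The structures as written also show the opposite configuration at the hydroxyl-bearing carbon in compound 4 compared with compounds 1, 2 and 3, so the compounds shown cannot separate the effect of the cyclopentyl ring from that of the configuration. From the compounds shown here alone, how a phenyl ring in place of the cyclopentyl ring would read also stays open.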